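Chloro in place of acetamido at the assay limit

The source may hold more compounds than are shown below. What is called first, only, known or untested is meant among the compounds shown, and "the series" means these compounds.

Measured so far in a functional assay on RD cells (Homo sapiens) for inhibition, read by luminescence and ATP content, with a stated time of 72 h (a higher number here means that more compound is tolerated, a lower number that less compound is tolerated), as limits only
Compound 1 `CCCc1ccc(-c2ccc3ncc(-c4noc(CC)n4)cc3c2)cc1` gives > 7400 nM as a limit
Compound 2 `CCc1nc(-c2cnc3ccc(-c4ccc(NC(C)=O)cc4)cc3c2)no1` gives > 7400 nM as a limit

Compound 2 stands at > 7400 nM as a limit, with no number to place it in the series. Compound 3 `CCc1nc(-c2cnc3ccc(-c4ccc(Cl)cc4)cc3c2)no1` carries chloro in place of acetamido on an aromatic carbon. Among the measured compounds shown here, the one measured step at this place is a step that the two limits leave unreadable from compound 1 to compound 2 and it gives no size. With propyl in compound 1 and acetamido in compound 2, the evidence is the limit of > 7400 nM in this assay, at which 2 of the 2 values shown sit, and no step beyond the scatter is expected in this assay for chloro. The expected change is a step that the limit leaves unreadable from compound 2 to compound 3 as an estimate only. For compound 3 the estimated value is 9000 nM with an expected range from 4000 nM to 20000 nM and another limit is the likely reading.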

Compound 3, half-maximal cytotoxic concentration: > 22200 nM
Compound 3 was reported as a limit; the forecaster's own chance of this, stated with the estimate: 75%; middle value at least 2.4-fold (0.39 log units) from the limit.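

Among the compounds shown here, compound 1, compound 2 and compound 3 all stand as limits in this assay, so no step among them can be read. The compounds shown leave open whether propyl, acetamido or chloro changes the half-maximal cytotoxic concentration at all.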